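Carbonyl aryl exchange from compound 2 to compound 3

The source may hold more compounds than are shown below. What is called first, only, known or untested is meant among the compounds shown, and "the series" means these compounds.

Compound 2 `COc1cc(-c2cc(/C=C/C(=O)c3ccc(Cl)c(Cl)c3)[nH]n2)cc(OC)c1OC` gives 31% in a functional assay on NCI-H460 cells (Homo sapiens) for cytotoxicity, read by sulforhodamine B assay, with a stated time of 48 h, tested at 10 uM (on this read-out higher numbers stand for a weaker effect at the one concentration tested and lower numbers for a stronger effect), the higher of the two numbers in hand; compound 1 `COc1ccc(-c2cc(/C=C/C(=O)c3ccc(N)cc3)[nH]n2)cc1` gives -40% in this assay, a gap beyond the scatter. Compound 3 `COc1ccc(C(=O)/C=C/c2cc(-c3cc(OC)c(OC)c(OC)c3)n[nH]2)cc1` differs from compound 2 by 4-methoxyphenyl in place of 3,4-dichlorophenyl on a carbonyl carbon. For the measured compounds named here, no measured pair isolates this exchange, so the size of the step is uncertain; a small shift toward a weaker effect, roughly of the size of the scatter, seems likeliest. Compound 3 is therefore expected to give 42% in this assay, within 5% to 78%. The step of a number 11 percentage points higher from compound 2 to compound 3 (beyond the scatter) is expected to be modest.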

Compound 3, a percentage reported as activity, at one concentration (the size of the read-out at that concentration, not a potency): -63%
Estimate against measurement, compound 3: 105 percentage points above, outside the stated range (below it).
By their numbers in this assay, from the lowest: compound 3; then compound 1; then compound 2.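

For the compounds shown here, on a carbonyl carbon, 4-methoxyphenyl in place of 3,4-dichlorophenyl gives a number 94 percentage points lower from compound 2 to compound 3 (beyond the scatter) in this assay, the first step that isolates a single place. This position is therefore far from neutral, and this one exchange, with the rest of the structure held fixed, is enough to move the read-out to a much stronger effect. Nothing in hand bears on the reason for this step. Still open, going by these compounds, is whether the shift follows from the methoxy group entering or the two chlorines leaving: an unsubstituted phenyl or a 4-chlorophenyl on the same carbonyl carbon would separate the two.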